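Methyl on the side-chain amine of the sulfone series

This account rests on a few compounds, and the source may have more. Where it says the series, first, only, none or still open, it means among the compounds named here.

compound 1, `NCCn1cc(S(=O)(=O)c2ccccc2)c2ccccc21`: 25 nM
compound 2, `NCCn1cc(S(=O)(=O)c2ccccc2)c2ccc(Cl)cc21`: 141 nM
compound 3, `NCCn1cc(S(=O)(=O)c2ccccc2)c2cc(F)ccc21`: 27 nM

Of the compounds shown here, three have been measured in an assay on HeLa cells for binding affinity to 5-hydroxytryptamine receptor 6 (Homo sapiens); on this read-out higher numbers stand for weaker inhibition and lower numbers for stronger inhibition. Compound 1 gives the lowest of the three numbers, but its nearest neighbour, compound 3, sits within the scatter of it, so no order between these two can be read from the data; the step of a 1.1-fold higher number from compound 1 to compound 3 (0.03 log units; within the scatter) is not a change. Only compound 2 stands apart, with the step of a 5.6-fold higher number from compound 1 to compound 2 (0.75 log units; beyond the scatter).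

Compound 4, `CNCCn1cc(S(=O)(=O)c2ccccc2)c2ccccc21`, is not yet measured. It differs from compound 1 in one place: methyl in place of hydrogen on an amine nitrogen. Neither of the two measured steps bears on this change. Among the compounds with values here, both of them place a halogen on an aromatic carbon of the shared core and leave the 2-aminoethyl chain untouched, and the one step beyond the scatter, from compound 1 to compound 2, concerns chloro and not the amine. There is therefore no measured guide for a methyl on the amine nitrogen, and the plain expectation is a step that stays within the scatter: a 1.2-fold higher number from compound 1 to compound 4 (0.08 log units; within the scatter). On that basis compound 4 is estimated at 30 nM in this assay, with a range of 10 nM to 90 nM to allow for an unmeasured kind of change.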

Compound 4, inhibition constant: 15.5 nM
Estimate against measurement, compound 4: 1.9-fold (0.29 log units) above, within the range that was stated.
By their numbers in this assay, from the lowest: compounds 4, 1 and 3 (each within the scatter of the next); then compound 2.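

In this assay, within the data shown here, the change from 2-aminoethyl to 2-(methylamino)ethyl gives a 1.6-fold lower number from compound 1 to compound 4 (0.21 log units; within the scatter), so this is the first read on the side chain rather than the aromatic part of the shared core, and it shows that methyl can take the place of hydrogen on this amine nitrogen without a step beyond the scatter. The direction of the step cannot be read as a gain, and the result supports only the statement that compound 1 and compound 4 are not told apart by this read-out, while the single added carbon leaves the number in the same range. No measured information accompanies the result that would account for it.

Still open, from the compounds shown here alone, is how far this position tolerates more than one methyl: a dimethylamino group, an ethyl on the nitrogen or a longer chain between the nitrogen and the core could each behave differently in this assay. Also open, going by these compounds, is whether the 2-(methylamino)ethyl chain gives the same kind of step when combined with the chloro of compound 2 or the fluoro of compound 3.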